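Aryl swap on the urea nitrogen: compound 3 to compound 4

The compounds below may be only part of what the source reports. "The series", "measured", "known", "first", "only" and "open" are said of these compounds alone.

In an assay on isolated protein for inhibition of STE20-like serine/threonine-protein kinase (Homo sapiens), read by thermal shift assay, tested at 10 uM (on this read-out lower numbers stand for weaker stabilisation of the target and higher numbers for stronger stabilisation of the target against heat), compound 3 `Cc1cc(C)cc(NC(=O)Nc2cc(C(C)(C)C)nn2-c2ccccc2)c1` gives 2.4 degrees C, the second highest of the three numbers. Compound 1 `Cc1ccccc1NC(=O)Nc1cc(C(C)(C)C)nn1-c1ccccc1` gives 7.1 degrees C and compound 2 `CCOc1ccc(NC(=O)Nc2cc(C(C)(C)C)nn2-c2ccccc2)cc1` gives 1.1 degrees C. The steps of a number 4.7 degrees C lower from compound 1 to compound 3 (beyond the scatter) and a number 6.0 degrees C lower from compound 1 to compound 2 (beyond the scatter) show that losing 2-methylphenyl on the amide-type nitrogen costs a large amount, whereas a number 1.3 degrees C higher from compound 2 to compound 3 (beyond the scatter) shows only a modest difference between the two other aryls. Compound 4 `CC(C)(C)c1cc(NC(=O)Nc2ccc(F)c(F)c2)n(-c2ccccc2)n1` differs from compound 3 by 3,4-difluorophenyl in place of 3,5-dimethylphenyl on an amide-type nitrogen. Going by the values given here, no measured step covers a fluorinated aryl; an aryl other than 2-methylphenyl is expected to stay in the low range, with a change within or only modestly beyond the scatter in either direction. Compound 4 is therefore estimated at 2.3 degrees C (range 0.5 degrees C to 5 degrees C), an expected step of a number 0.10 degrees C lower from compound 3 to compound 4 (within the scatter).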

Compound 4, shift of the target's melting temperature: 5.5 degrees C
For compound 4 the middle estimate is 3.2 degrees C below the measured one; the whole stated range lies below it.
By their numbers in this assay, from the lowest: compound 2; then compound 3; then compound 4; then compound 1.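

In this assay, 3,4-difluorophenyl on the amide-type nitrogen gives a number 3.1 degrees C higher from compound 3 to compound 4 (beyond the scatter) and, against 4-ethoxyphenyl, a number 4.4 degrees C higher from compound 2 to compound 4 (beyond the scatter); a high number at this position therefore does not require 2-methylphenyl. That group still keeps the lead, since the change away from it gives a number 1.6 degrees C lower from compound 1 to compound 4 (beyond the scatter). No measurement on hand accounts for the gain with 3,4-difluorophenyl.

Going by these compounds, whether the gain rests on fluorine or on the placement of the two substituents remains open. A chlorine or a nitrile on the aryl, or an aryl bearing an amine, would test how far it extends.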